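Flipping one stereocentre in a protein-binding pair

The source may hold more compounds than are shown below. What is called first, only, known or untested is meant among the compounds shown, and "the series" means these compounds.

compound 1 `CC[C@H](c1ccc(C(=O)O)c(Oc2cccc(Cl)c2)c1OC)N1CCC[C@H](n2cc(C)c(=O)[nH]c2=O)C1` - 0.015
compound 2 `CCC[C@@H](c1ccc(C(=O)O)c(Oc2cccc(Cl)c2)c1OC)N1CCC[C@H](n2cc(C)c(=O)[nH]c2=O)C1` - 0.065

In an ADME assay on a cell-free system (plasma, Homo sapiens) for protein binding, using equilibrium dialysis, with a stated time of 5 h, tested at 10 uM (on this read-out lower numbers stand for a smaller free fraction and higher numbers for a larger free fraction), compound 2 stands highest of the two at 0.065 and its gap to compound 1 lies beyond the scatter. Compound 3 `CCC[C@H](c1ccc(C(=O)O)c(Oc2cccc(Cl)c2)c1OC)N1CCC[C@H](n2cc(C)c(=O)[nH]c2=O)C1` has the same atoms and bonds as compound 2 and differs only in configuration as drawn: the two compounds have the same atoms and bonds and differ only in configuration as drawn: 1 of 2 stereo elements differ; a stereocentre at a saturated chain carbon is drawn S in compound 2 and R in compound 3 with a stereocentre at a saturated chain carbon drawn S in compound 2 and R in compound 3. Among the measured compounds shown here, no measured pair shows the size of such a change. For the measured compounds named here, the only lower reference is compound 1 at 0.015 so a small downward move, no larger than the scatter, is expected. The estimated move is a 1.9-fold lower number from compound 2 to compound 3 (0.27 log units; within the scatter) in this assay for now. In this assay compound 3 is estimated to give 0.035 with a range from 0.012 to 0.09 as the expected span.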

Compound 3, unbound fraction in the plasma assay: 0.034
Compound 3: middle estimate off by 1.0-fold (0.01 log units), on the high side, and the stated range covers the measured number.
By their numbers in the plasma assay, from the lowest: compound 1; then compounds 3 and 2 (each within the scatter of the next).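

In the plasma assay compound 2 gives 0.065 and compound 3 gives 0.034, so inverting this chain carbon gives a 1.9-fold lower number from compound 2 to compound 3 (0.28 log units; within the scatter) and shows no clear effect of configuration here, in a clean test of that one feature: the fact that compounds 2 and 3 differ only in the configuration as drawn. In the plasma assay the step of a 2.3-fold higher number from compound 1 to compound 3 (0.36 log units; beyond the scatter) goes with methyl in place of hydrogen on a saturated chain carbon, so the added methyl registers where the inversion does not. In a physicochemical assay for lipophilicity, using the shake flask method, in phosphate buffer, measured as octanol-water partition, at pH 7.4 (a higher number here means a more lipophilic compound, a lower number a more polar compound), compound 2 gives 0.13 and compound 3 gives 0.08, and the inversion gives a number 0.05 log units lower from compound 2 to compound 3 (within the scatter) and again shows no clear change.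

From the compounds shown here alone, whether a longer chain or a chain carrying a hydroxyl group would raise the free fraction further stays open. So does the effect of the same inversion on compound 1.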